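Fluoro for Acetyl in a Urea Series Tested on Rice

This account rests on a few compounds, and the source may have more. Where it says the series, first, only, none or still open, it means among the compounds named here.

Three compounds have been measured in an ADME assay on the whole organism with Oryza sativa as the target, tested at 1 uM; a higher number here means a weaker effect of the compound at the concentration tested, a lower number a stronger effect:

Compound 1, `CC(=O)c1cccc(NC(=O)N[C@@H](C)c2ccccc2)c1`, gives 95%.
Compound 2, `CC(=O)c1ccc(NC(=O)N[C@H](C)c2ccccc2)cc1`, gives 93%.
Compound 3, `C[C@H](NC(=O)Nc1cccc(F)c1)c1ccccc1`, gives 94%.

Compound 3 differs from compound 1 by fluoro in place of acetyl on an aromatic carbon, and this step gives a number 1 percentage points lower from compound 1 to compound 3 (within the scatter). Compound 2 has the same atoms as compound 1, joined differently; the difference between the two cores is not broken down here. Compound 4, `C[C@@H](NC(=O)Nc1ccc(F)cc1)c1ccccc1`, is not yet measured. It differs from compound 2 by fluoro in place of acetyl on an aromatic carbon. The place is not the same word for word: in compound 3 the fluoro is meta to a large group, in compound 4 it is para to a large group, so this is the same kind of change, not the same one. From compound 2 to compound 4 a step of no change at the digits printed from compound 2 to compound 4 (within the scatter) is expected in this assay, resting on the earlier step of a number 1 percentage points lower from compound 1 to compound 3 (within the scatter), which stayed within the scatter. Compound 4 is therefore estimated at 93%, between 85% and 99%.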

Compound 4, a percentage reported as activity, at one concentration (the size of the read-out at that concentration, not a potency): 96%
For compound 4 the middle estimate is 3 percentage points below the measured one, and the stated range covers the measured number.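

In this assay, fluoro in place of acetyl on an aromatic carbon gives a number 3 percentage points higher from compound 2 to compound 4 (within the scatter). Set beside the earlier step, the change reads alike on both cores: the same change on two cores in this assay, a number 1 percentage points lower (within the scatter) from compound 1 to compound 3 and a number 3 percentage points higher (within the scatter) from compound 2 to compound 4, 4 percentage points apart, within the scatter of two such steps This shows only that the change left the number within the scatter on these two cores at the single concentration tested; it does not show that the two steps are truly identical, nor that the same would hold on any other core.

The compounds shown leave open whether another group in place of acetyl, such as an amine or a carboxylic acid, would move the number beyond the scatter. From the compounds shown here alone, they also contain no step beyond the scatter in this assay, so how such a step would carry between cores remains unknown.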